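This account rests on a few compounds, and the source may have more. Where it says the series, first, only, none or still open, it means among the compounds named here.

Measured so far:
- compound 1, `CCc1ccc(-c2nc3c(c(C)nn3-c3ccccc3)c(-c3ccccc3C#N)c2C#N)cc1`: 2400 nM
- compound 2, `C#Cc1ccccc1-c1c(C#N)c(-c2ccc(CC)cc2)nc2c1c(C)nn2-c1ccccc1`: 46000 nM
- compound 3, `CCCc1ccc(-c2nc3c(c(C)nn3-c3ccccc3)c(-c3ccccc3O)c2C#N)cc1`: 6500 nM

In a physicochemical assay for solubility, read by spectrophotometry, in phosphate buffer, with a stated time of 18 h, at pH 7.4 (on this read-out higher numbers stand for higher solubility and lower numbers for lower solubility), compound 3 stands second highest of the three numbers; compound 1 lies closest to it, and compound 2 furthest above it. For the measured compounds named here, the one step that can be followed between two measured compounds is a 19-fold higher number from compound 1 to compound 2 (1.28 log units; beyond the scatter), a large rise brought about by one exchange of a small group on the outer ring.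

Compound 4, `Cc1nn(-c2ccccc2)c2nc(-c3ccc4c(c3)OCCO4)c(C#N)c(-c3ccccc3O)c12`, has not yet been measured in this assay. It differs from compound 3 in one place: 2,3-dihydro-1,4-benzodioxin-6-yl in place of 4-propylphenyl on an aromatic carbon. Going by the values given here, no measured pair shows this exchange or one like it, so the step from compound 3 to compound 4 has no direct precedent among the numbers here. Among the compounds with values here, the only measured step, from compound 1 to compound 2, concerns a different position and a different kind of group, and it can say little about what a change on the carbon next to the ring nitrogen will do.

On that basis, the expectation for compound 4 is a modest step, a 1.7-fold higher number from compound 3 to compound 4 (0.23 log units; within the scatter), with wide uncertainty. Compound 4 is therefore estimated at 11000 nM, within a range from 3500 nM to 35000 nM.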

Compound 4, solubility: 11000 nM
For compound 4 middle estimate and measured number coincide at the digits printed; the range from low to high includes it.
By their numbers in this assay, from the lowest: compound 1; then compounds 3 and 4 (each within the scatter of the next); then compound 2.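

At the aromatic carbon next to the ring nitrogen and ortho to a cyano group, this assay gives a 1.7-fold higher number from compound 3 to compound 4 (0.23 log units; within the scatter) when 2,3-dihydro-1,4-benzodioxin-6-yl takes the place of 4-propylphenyl. For the compounds shown here, a substituent with one aromatic ring of carbon only and 0 hydrogen-bond acceptors has thus been exchanged for one with 2 oxygen atoms and 2 hydrogen-bond acceptors, yet compound 3 and compound 4 cannot be told apart on this read-out, whereas the only earlier step was large and lay in a different place. No measurement among these compounds accounts for this outcome.

The compounds shown leave open what an amine or a carboxylic acid on the aromatic ring at this same carbon would do to the read-out, since here only one pair of groups has been compared at this carbon. They also leave open whether the exchange would give a similar step if the 2-hydroxyphenyl group shared by compound 3 and compound 4 were replaced by a 2-cyanophenyl or a 2-ethynylphenyl group.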